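A few compounds are considered here, and "the series" means these few. Any claim that something is new, unique, unknown or untested is made for them only; others in the source may bear on it.

Measured so far:
compound 1 `O=C(COc1ccc(C(=O)/C=C/c2cccc(Br)c2)cc1)N[C@H]1CCOC1=O`: 7890 nM
compound 2 `CC(C)c1ccc(NCC(=O)N[C@H]2CCOC2=O)cc1`: > 64000 nM

Among the compounds with values here, compound 1 is the only compound here that carries an actual number. In a functional assay on PC-3 cells (Homo sapiens) for antiproliferative activity, read by MTT assay, with a stated time of 72 h (on this read-out lower numbers stand for stronger inhibition and higher numbers for weaker inhibition), compound 1 gives 7890 nM. Compound 2 shows only a limit of this assay, > 64000 nM, so no number was reached for it (the limit of > 64000 nM in this assay, at which 1 of the 2 values shown sits). Compound 2 is built on a different core from compound 1, so its limit tells nothing about the step that follows.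

Compound 3 `O=C(COc1ccc(C(=O)/C=C/c2ccc(F)cc2)cc1)N[C@H]1CCOC1=O` keeps the core of compound 1 and differs in one place: 4-fluorophenyl in place of 3-bromophenyl on a double-bonded chain carbon bound to a double-bonded chain carbon. Within the data shown here, no measured pair in this set shows what such a swap of one halogen-bearing ring for another does, so the expectation rests on compound 1 alone and on the small size of the change, which stays within that one group. The step is expected to be small, at most a modest loss that may well sit within the usual scatter: a 1.5-fold higher number from compound 1 to compound 3 (0.18 log units; within the scatter). Compound 3 is therefore estimated at 12000 nM, with a plausible range from 4000 nM to 40000 nM.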

Compound 3, half-maximal inhibitory concentration: 15600 nM
Compound 3: middle estimate off by 1.3-fold (0.11 log units), on the low side, and the stated range covers the measured number.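

In this assay, putting 4-fluorophenyl in place of 3-bromophenyl on a double-bonded chain carbon bound to a double-bonded chain carbon gives a 2.0-fold higher number from compound 1 to compound 3 (0.30 log units; within the scatter). Within the data shown here, this is the first step in the set that can be read, and it shows that this position accepts a change in both the halogen and its location on the phenyl ring without a difference that stands clear of ordinary measurement variation; this holds for this one pair only, and the shared core stays untouched throughout. Nothing measured here offers an explanation for how closely the two compounds agree.

Since the halogen and its location changed together, the compounds shown cannot reveal what either change does alone, and a 4-bromophenyl or 3-fluorophenyl group would be needed to separate the two. From the compounds shown here alone, it also remains open whether this position would tolerate a quite different kind of group, such as a phenyl ring bearing an amine or a carboxylic acid, or a plain phenyl ring with no halogen at all.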